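This account rests on a few compounds, and the source may have more. Where it says the series, first, only, none or still open, it means among the compounds named here.

Two compounds of this series have so far been run in a functional assay on MCF7 cells (Homo sapiens) for cytotoxicity, read by MTT assay, with a stated time of 48 h; a higher number here means a weaker inhibitor, a lower number a stronger inhibitor. Compound 1 `CC(=O)Nc1ccc2nc(SCC(=O)NCc3ccccc3)sc2c1` gives 17600 nM, and compound 2 `COc1ccccc1C(=O)Nc1ccc2nc(SCC(=O)NCc3ccccc3)sc2c1` gives 17200 nM. Among the compounds with values here, the single measured step, a 1.0-fold lower number from compound 1 to compound 2 (0.01 log units; within the scatter), concerns the acyl group on the anilide nitrogen and leaves the number unchanged. Among the two numbers, compound 1 stands at the higher end, with compound 2 as its nearest neighbour at a gap within the scatter.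

Compound 3 `CNC(=O)CSc1nc2ccc(NC(C)=O)cc2s1` differs from compound 1 by hydrogen in place of phenyl on a saturated chain carbon bound to an amide-type nitrogen. Within the data shown here, no measured step touches this part of the molecule, and the one step known, at the other end of the shared core, was flat. Nothing here supports expecting a shift beyond the scatter in this assay in either direction. For compound 3 the expected value is 18000 nM, with a range of 7000 nM to 45000 nM. This estimate means a step of a 1.0-fold higher number from compound 1 to compound 3 (0.01 log units; within the scatter).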

Compound 3, half-maximal inhibitory concentration: > 100000 nM
Compound 3: no number, only a limit (the forecaster's own chance of this, stated with the estimate: 10%); middle value at least 5.5-fold (0.74 log units) away from the limit.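

The benzylamino to methylamino change opens a part of the molecule that the earlier pair did not touch, and here the number moves: an at least 5.6-fold higher number from compound 1 to compound 3 (0.75 log units; beyond the scatter). In this assay compound 3 gives > 100000 nM, which is a limit and not a number, so the step has a lower bound only and its full size stays unknown: the limit of > 100000 nM in this assay, at which 1 of the 3 values shown sits.
Set against the acyl change, a 1.0-fold lower number from compound 1 to compound 2 (0.01 log units; within the scatter), the phenyl end is the only place so far where a change goes beyond the scatter, and this rests on a single pair.

Only benzyl and methyl are shown at this place, so it remains open whether the aromatic ring or simply the size of the group decides the outcome. A cyclohexylmethyl group, a plain n-butyl chain or a longer phenethyl chain here would separate these readings.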